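The compounds below may be only part of what the source reports. "The series", "measured", "known", "first", "only" and "open" are said of these compounds alone.

Measured in a functional assay on MCF7 cells (Homo sapiens) for cytotoxicity, read by CellTiter-Glo, with a stated time of 5 days; on this read-out higher numbers stand for weaker inhibition and lower numbers for stronger inhibition:
- compound 1 `CC/C(=C(/c1ccc(/C=C/C(=O)O)cc1)c1ccc2[nH]ncc2c1)c1ccccc1Cl`: 2 nM
- compound 2 `CC/C(=C(/c1ccc(/C=C/C(=O)O)cc1)c1ccc2[nH]ncc2c1)c1ccc(C#N)cc1`: 47 nM
- compound 3 `CC/C(=C(/c1ccc(/C=C/C(=O)O)cc1)c1ccc2[nH]ncc2c1)c1cccnc1C`: 200 nM

Compound 3 has the highest number of the three. Compound 4 `CC/C(=C(/c1ccc(/C=C/C(=O)O)cc1)c1ccc2[nH]ncc2c1)c1ccncc1C` is unmeasured and carries 3-methylpyridin-4-yl in place of 2-methylpyridin-3-yl on a double-bonded chain carbon bound to a double-bonded chain carbon and a saturated chain carbon.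

Changes at this place have been large: a 24-fold higher number from compound 1 to compound 2 (1.37 log units; beyond the scatter) and a 100-fold higher number from compound 1 to compound 3 (2.00 log units; beyond the scatter). The closest comparison is smaller: a 4.3-fold higher number from compound 2 to compound 3 (0.63 log units; beyond the scatter). Going by the values given here, no measured step isolates a swap between two methylpyridinyl groups. A modest move towards a lower number is expected in this assay, a 2.0-fold lower number from compound 3 to compound 4 (0.30 log units; within the scatter). For compound 4 the estimated value is 100 nM, with an expected range of 25 nM to 400 nM.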

Compound 4, half-maximal inhibitory concentration: 16 nM
Compound 4: the middle estimate sits 6.3-fold (0.80 log units) above what was measured; the measured number lies below the stated range.
By their numbers in this assay, from the lowest: compound 1; then compound 4; then compound 2; then compound 3.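

In this assay, the position on this double-bonded chain carbon separates two methylpyridinyl groups built from the same atoms, with 3-methylpyridin-4-yl in place of 2-methylpyridin-3-yl (a 13-fold lower number from compound 3 to compound 4 (1.10 log units; beyond the scatter)). This group also gives a lower number than 4-cyanophenyl (a 2.9-fold lower number from compound 2 to compound 4 (0.47 log units; beyond the scatter)), but 2-chlorophenyl stays lowest (an 8.0-fold higher number from compound 1 to compound 4 (0.90 log units; beyond the scatter)). Nothing available explains the gap between the two methylpyridinyl groups. The shown compounds do not separate the part played by the ring nitrogen from that of the methyl. An unsubstituted pyridin-4-yl or a 2-methylphenyl group at this place would bear on that.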